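Rearranging One Side Chain on a Shared Core

This account rests on a few compounds, and the source may have more. Where it says the series, first, only, none or still open, it means among the compounds named here.

In an ADME assay on the whole organism for inhibition, with Oryza sativa as the target, with a stated time of 4 days (a lower number here means a stronger inhibitor, a higher number a weaker inhibitor), compound 1 (`CCNc1nc(Cl)nc(N[C@H](C)c2ccccc2)n1`) gives 14100 nM, and compound 2 (`CCCN(CC)c1nc(Cl)nc(N[C@@H](C)c2ccccc2)n1`) gives 479 nM. Compound 2 therefore holds the lower of the two numbers, by a gap beyond the scatter, which makes it the stronger inhibitor so far. These two compounds differ in more than one place, so the gap cannot be assigned to any single group.

Compound 3 (`CCC(CC)Nc1nc(Cl)nc(N[C@@H](C)c2ccccc2)n1`) has the same atoms as compound 2, joined differently: (pentan-3-yl)amino in place of ethyl(propyl)amino on an aromatic carbon. Among the measured compounds shown here, no measured pair shows this kind of swap, so the expectation rests on thin evidence. The incoming group keeps a hydrogen on its nitrogen, as does compound 1 at 14100 nM, but it carries a larger chain than that compound, with the same atoms as the group in compound 2. A partial move toward a weaker inhibitor therefore seems likely in this assay, probably a little beyond the scatter. The expected size of this rise is a 2.3-fold higher number from compound 2 to compound 3 (0.36 log units; beyond the scatter). For compound 3, the estimated value is 1100 nM, with an expected range of 200 nM to 5500 nM.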

Compound 3, half-maximal inhibitory concentration: 35500 nM
Compound 3: middle estimate off by 32-fold (1.51 log units), on the low side; the whole stated range lies below it.
By their numbers in this assay, from the lowest: compound 2; then compound 1; then compound 3.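

In this assay, this position proves highly sensitive to how the same atoms are joined: (pentan-3-yl)amino in place of ethyl(propyl)amino gives a 74-fold higher number from compound 2 to compound 3 (1.87 log units; beyond the scatter), although the heavy-atom count stays the same. The number of carbon and nitrogen atoms in this side chain therefore does not by itself settle the value, and the step is not a small adjustment. Two things change together in this swap, the arrangement of the carbon chain and the hydrogen-bond donor that enters with the hydrogen on the nitrogen, and no measurement at hand accounts for the step.

The compounds shown leave open which of these two changes carries the step: a straight pentylamino chain would keep the hydrogen on the nitrogen while altering the arrangement of the carbons, whereas diethylamino would have no such hydrogen and a shorter chain. Also open, as far as these compounds go, is whether the step would keep its size with a methoxy group in place of the chloro group on the shared core.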